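A few compounds are considered here, and "the series" means these few. Any claim that something is new, unique, unknown or untested is made for them only; others in the source may bear on it.

Compound 1 `CCCn1nc(C(=O)N[C@H]2COc3ccccc3N(C)C2=S)nc1Cc1ccccc1` gives 288 nM in a functional assay on HT-29 cells (Homo sapiens) for inhibition, read by luminescence and CellTiter-Glo, with a stated time of 24 h; on this read-out higher numbers stand for an effect only at larger amounts of compound and lower numbers for an effect already at smaller amounts. Among the compounds with values here, compound 2 `CN1C(=S)[C@@H](NC(=O)c2nc(Cc3ccccc3)n(C3CCCC3)n2)COc2ccccc21` gives 3530 nM in this assay, the highest of the two numbers; the only measured step, a 12-fold higher number from compound 1 to compound 2 (1.09 log units; beyond the scatter), was large. Compound 3 `CN1C(=S)[C@@H](NC(=O)c2nc(Cc3ccccc3)n(Cc3ccccc3)n2)COc2ccccc21` differs from compound 2 by benzyl in place of cyclopentyl on an aromatic nitrogen. Within the data shown here, no measured step covers this exact change; the one step bearing on the group at this aromatic nitrogen, a 12-fold higher number from compound 1 to compound 2 (1.09 log units; beyond the scatter), shows that this group shifts the read-out beyond the scatter, but the direction for benzyl is not known from the data. A moderate step toward lower numbers is expected, with wide uncertainty. For compound 3 the expected step is a 2.4-fold lower number from compound 2 to compound 3 (0.37 log units; beyond the scatter). Compound 3 is expected at 1500 nM, with an estimated range of 300 nM to 7000 nM.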

Compound 3, half-maximal effective concentration: 414 nM
Estimate against measurement, compound 3: 3.6-fold (0.56 log units) above; the range from low to high includes it.
By their numbers in this assay, from the lowest: compounds 1 and 3 (each within the scatter of the next); then compound 2.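

In this assay, cyclopentyl does not speak for all groups on this aromatic nitrogen: benzyl in its place gives an 8.5-fold lower number from compound 2 to compound 3 (0.93 log units; beyond the scatter). Propyl and benzyl cannot be told apart at this position, with a 1.4-fold higher number from compound 1 to compound 3 (0.16 log units; within the scatter), so the high number belongs to cyclopentyl alone among the three groups. Nothing available gives a reason for either step.

From the compounds shown here alone, whether an amine, a carboxylic acid or a longer chain on this nitrogen would stay with propyl and benzyl or move toward cyclopentyl remains open. Also open, going by these compounds, is how a fluorine on the benzyl ring would shift the number.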